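Adding a 2-hydroxyethyl group to compound 1

The source may hold more compounds than are shown below. What is called first, only, known or untested is meant among the compounds shown, and "the series" means these compounds.

Among the compounds with values here, in a functional assay on NCI-H1993 cells (Homo sapiens) for inhibition, read by CCK-8 assay, with a stated time of 72 h (on this read-out higher numbers stand for weaker inhibition and lower numbers for stronger inhibition), compound 1 `CC(c1cc2cccnc2cc1F)n1cnc2ncc(-c3cn[nH]c3)nc21` gives 187 nM, the only number available so far, so it cannot yet be ranked against any other compound. Its relative, compound 2 `CCC(c1cc2cccnc2cc1F)n1cnc2ncc(-c3cn[nH]c3)nc21`, offers no comparison, as the result for compound 2 reads "not determined" (no result reported). Compound 3 `CC(c1cc2cccnc2cc1F)n1cnc2ncc(-c3cnn(CCO)c3)nc21` keeps the core of compound 1 but carries 2-hydroxyethyl in place of hydrogen on an aromatic nitrogen, turning 1H-pyrazol-4-yl into 1-(2-hydroxyethyl)-1H-pyrazol-4-yl (2-hydroxyethyl in place of hydrogen on an aromatic nitrogen). Within the data shown here, no measured step between compounds is available to guide this change, so any expectation is a judgement with wide margins. A modest move toward stronger inhibition in this assay is expected, rather than a large one. The estimated change is a 2.5-fold lower number from compound 1 to compound 3 (0.40 log units; beyond the scatter). For compound 3 the expected value is 75 nM, within an estimated range of 18 nM to 300 nM.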

Compound 3, half-maximal inhibitory concentration: 175 nM
Compound 3: middle estimate off by 2.3-fold (0.37 log units), on the low side; the measured number falls inside the stated range.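

In this assay, within the data shown here, the step of a 1.1-fold lower number from compound 1 to compound 3 (0.03 log units; within the scatter) is the first reading at this position, and it leaves the two compounds indistinguishable. The aromatic nitrogen of the 1H-pyrazol-4-yl group can therefore carry 2-hydroxyethyl in place of hydrogen with no difference beyond the scatter, so in this pair the free hydrogen on that nitrogen is not needed to keep the cellular number. No independent measurement is available to explain this result.

One substitution cannot show how far this tolerance extends, for example to a plain ethyl or methyl group on the same nitrogen, where the hydroxyl would be absent. It also leaves open whether a longer chain such as 3-hydroxypropyl, an amine such as 2-aminoethyl, or a carboxylic acid would behave in the same way.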